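Replacing a methylpyridinyl with a trifluoromethylphenyl on the piperazine

This account rests on a few compounds, and the source may have more. Where it says the series, first, only, none or still open, it means among the compounds named here.

Compound 1 `CN(C)C(=O)c1cccnc1NCCCN1CCN(c2ccccc2OC(F)(F)F)CC1` gives 3.16 nM in a functional assay for antagonist activity at Alpha-1A adrenergic receptor (Oryctolagus cuniculus); a higher number here means weaker binding, a lower number tighter binding.
Compound 2 `CN(C)C(=O)c1cccnc1NCCCN1CCN(c2ccccc2OCC(F)(F)F)CC1` gives 0.1 nM in this assay.
Compound 3 `Cc1cnccc1N1CCN(CCCNc2ncccc2C(=O)N(C)C)CC1` gives 200 nM in this assay.

Compound 3 has the highest number of the three, so it binds the least tightly: its value is far from that of compound 1 and still further from that of compound 2, both gaps beyond the scatter. For the measured compounds named here, the one step recorded between measured compounds, a 32-fold lower number from compound 1 to compound 2 (1.50 log units; beyond the scatter), shows that a small change in the group on the oxygen on the aromatic ring can move the number a great deal.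

Compound 4 `CN(C)C(=O)c1cccnc1NCCCN1CCN(c2ccccc2C(F)(F)F)CC1` carries a change of a different kind: 2-(trifluoromethyl)phenyl in place of 3-methylpyridin-4-yl on an amine nitrogen in a ring. Going by the values given here, no measured step covers this exchange of one aromatic ring for another, so the best guide is the comparison of compound 3 with compound 1, which also carries a phenyl ring bearing fluorinated substitution on this nitrogen and gives a much lower number. Compound 4 is therefore expected to land near compound 1, meaning a 40-fold lower number from compound 3 to compound 4 (1.60 log units; beyond the scatter), a large step toward tighter binding. The estimate for compound 4 is 5 nM, with a range of 1 nM to 30 nM.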

Compound 4, dissociation constant: 12.6 nM
Estimate against measurement, compound 4: 2.5-fold (0.40 log units) below, and the stated range covers the measured number.
By their numbers in this assay, from the lowest: compound 2; then compound 1; then compound 4; then compound 3.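

In this assay, the exchange of 3-methylpyridin-4-yl for 2-(trifluoromethyl)phenyl on the amine nitrogen now has a direct reading, a 16-fold lower number from compound 3 to compound 4 (1.20 log units; beyond the scatter) with nothing else in the structure altered, so the aromatic group at this position matters a great deal. Compound 4 also adds a third group on the same phenyl ring and shows that the linkage counts: trifluoromethyl in place of trifluoromethoxy gives a 4.0-fold higher number from compound 1 to compound 4 (0.60 log units; beyond the scatter) as a modest step, while trifluoromethyl in place of 2,2,2-trifluoroethoxy gives a 130-fold higher number from compound 2 to compound 4 (2.10 log units; beyond the scatter) as a large one, so among these three compounds both groups attached through oxygen give lower numbers than the group attached directly, and none goes against this. Nothing presented here accounts for the size of any of these steps.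

The ring exchange changes two things at once, the ring itself and the group it carries, and an unsubstituted phenyl or a pyridine bearing trifluoromethyl would be needed to separate them. Going by these compounds, it also remains open whether a longer chain on the oxygen, such as 3,3,3-trifluoropropoxy, or a plain ethoxy would match 2,2,2-trifluoroethoxy.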